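The compounds below may be only part of what the source reports. "The series", "measured", "known", "first", "only" and "open" are said of these compounds alone.

Working notes on the series. On the shared core, a functional assay on OVCAR-3 cells (Homo sapiens) for inhibition, read by MTT assay, with a stated time of 24 h (a lower number here means a stronger inhibitor, a higher number a weaker inhibitor), gives these numbers: compound 1 `CC1(C)[C@H]2CC[C@]1(C)N(Cc1cn(-c3cccc(Cl)c3)nn1)C(=O)C2` (3-chlorophenyl) at 50 nM, compound 2 `CC1(C)[C@H]2CC[C@]1(C)N(Cc1cn(-c3ccc(O)cc3)nn1)C(=O)C2` (4-hydroxyphenyl) at 410 nM and compound 3 `CC1(C)[C@H]2CC[C@]1(C)N(Cc1cn(-c3ccccc3O)nn1)C(=O)C2` (2-hydroxyphenyl) at 90 nM on the same read-out. Compound 3 therefore cannot be separated from the chloro compound, the step being a 1.8-fold higher number from compound 1 to compound 3 (0.26 log units; within the scatter), but it stands clearly apart from the other phenol, with a 4.6-fold lower number from compound 2 to compound 3 (0.66 log units; beyond the scatter) as the step.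

Compound 4 `CC1(C)[C@H]2CC[C@]1(C)N(Cc1cn(-c3cccc(O)c3)nn1)C(=O)C2` is still unmeasured. It carries 3-hydroxyphenyl in place of 2-hydroxyphenyl on an aromatic nitrogen.

The step most relevant here is a 4.6-fold lower number from compound 2 to compound 3 (0.66 log units; beyond the scatter), which shows that moving the hydroxyl alone can matter. The step of an 8.2-fold higher number from compound 1 to compound 2 (0.91 log units; beyond the scatter) is of similar size. With only two phenols measured, a small rise in this assay is expected, probably within the scatter. The estimate is a 1.7-fold higher number from compound 3 to compound 4 (0.22 log units; within the scatter) (expected, not measured). Compound 4 is expected at 150 nM (estimated range 60 nM to 400 nM).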

Compound 4, half-maximal inhibitory concentration: 370 nM
Compound 4: the middle estimate sits 2.5-fold (0.39 log units) below what was measured, and the stated range covers the measured number.
By their numbers in this assay, from the lowest: compounds 1 and 3 (each within the scatter of the next); then compounds 4 and 2 (each within the scatter of the next).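

In this assay, 3-hydroxyphenyl does not hold the level of 2-hydroxyphenyl, with a 4.1-fold higher number from compound 3 to compound 4 (0.61 log units; beyond the scatter), and it cannot be separated from 4-hydroxyphenyl, with a 1.1-fold lower number from compound 2 to compound 4 (0.04 log units; within the scatter), so among the three phenols only 2-hydroxyphenyl stands apart. Hydroxy in place of chloro on an aromatic carbon gives a 7.4-fold higher number from compound 1 to compound 4 (0.87 log units; beyond the scatter), a direct exchange that the earlier compounds did not offer, so the match between compound 3 and compound 1 does not carry over to every phenol here. No supporting data bear on why the 2-hydroxyphenyl compound differs from the other two phenols.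

From the compounds shown here alone, whether 2-methoxyphenyl or 2-aminophenyl would stay with compound 3 or fall back to compound 4 remains open. Also open, going by these compounds, is how 2-chlorophenyl and 4-chlorophenyl would compare with compound 1.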